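The source may hold more compounds than are shown below. What is called first, only, known or untested is meant among the compounds shown, and "the series" means these compounds.

Measured so far in an ADME assay on Huh7.5.1 cells (Homo sapiens) for cytotoxicity, read by ATP content, with a stated time of 48 h; on this read-out lower numbers stand for higher toxicity in this test and higher numbers for lower toxicity in this test:

- compound 1, `Cc1ccccc1-c1nc(CN2CCC(C(=O)NCCCN3CCCCC3)CC2)c(C)o1`: 18100 nM
- compound 2, `CC[C@@H]1C[C@H](CC)CN(CCCNC(=O)C2CCN(Cc3nc(-c4c(F)cccc4F)oc3C)CC2)C1`: 12600 nM
- compound 3, `Cc1cccc(F)c1-c1nc(CN2CCC(C(=O)NCCCN3C[C@H](C)C[C@H](C)C3)CC2)c(C)o1`: 13000 nM

Compound 3 holds the second highest of the three numbers. Its nearest neighbour is compound 2, and the gap between the two, like the wider gap to compound 1, lies within the scatter of repeated measurements, so the three readings are best treated as one level of cytotoxicity. The aryl group on the shared core has been varied three ways without any separation appearing on this read-out.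

The next compound, compound 4, `COc1ccc(-c2nc(CN3CCC(C(=O)NCCCN4C[C@H](C)C[C@H](C)C4)CC3)c(C)o2)cc1OC`, differs from compound 3 in one place: 3,4-dimethoxyphenyl in place of 2-fluoro-6-methylphenyl on an aromatic carbon. Among the compounds with values here, no measured pair in the set spans this change, so there is no step to lean on; what is available is that the amide-linked piperidine chain and the core are kept and that three aryl variants so far fall together. On that basis the change is expected to give no step beyond the scatter, a 1.1-fold higher number from compound 3 to compound 4 (0.03 log units; within the scatter). Compound 4 is accordingly estimated at 14000 nM, with a range from 7000 nM to 30000 nM.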

Compound 4, half-maximal cytotoxic concentration: 57200 nM
Compound 4: the middle estimate sits 4.1-fold (0.61 log units) below what was measured; measured number outside the range, above it.
By their numbers in this assay, from the lowest: compounds 2, 3 and 1 (each within the scatter of the next); then compound 4.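

The aryl position on the aromatic carbon next to the ring nitrogen and next to the ring oxygen is not silent in this assay: 3,4-dimethoxyphenyl in place of 2-fluoro-6-methylphenyl gives a 4.4-fold higher number from compound 3 to compound 4 (0.64 log units; beyond the scatter), moving towards lower toxicity in this test, with the rest of the molecule unchanged. Within the data shown here, this is the only step so far that can be read across a single change, and it shows that the aryl group alone can move this read-out beyond the scatter. The change swaps fluorine and methyl for two methoxy groups and adds hydrogen-bond acceptors, but nothing available indicates which of these differences matters or why the number rises.

The compounds shown leave open whether both methoxy groups are needed, or whether a single methoxy group, a hydroxyl group or an unsubstituted phenyl at this position would give a similar number. They also leave open whether 3,4-dimethoxyphenyl would produce a comparable step alongside the piperidine chain end of compound 1 or the diethyl-substituted chain end of compound 2.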